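The compounds below may be only part of what the source reports. "The series", "measured", "known", "first", "only" and "open" are said of these compounds alone.

Working notes on the series

The compounds share the core of compound 1 `CCCCc1nc(C)c(CC(=O)OCC)c(=O)n1Cc1ccc(-c2ccccc2-c2noc(=O)[nH]2)cc1` and differ only in the chain on the oxygen next to a carbonyl group. In an ADME assay on microsomes from liver (Mus musculus) for metabolic stability, with a stated time of 30 min (a lower number here means that less of the compound is left, a higher number that more of the compound is left), compound 1 gives 12.9%; 78.4% (2 entries), two entries that do not agree, so that the several entries of compound 1 in this assay, 12.9%; 78.4% (2 entries) yields no single number to place it by. Compound 2 `CCCCc1nc(C)c(CC(=O)OC(C)C)c(=O)n1Cc1ccc(-c2ccccc2-c2noc(=O)[nH]2)cc1` gives 4% in this assay. Compound 3 `CCCCc1nc(C)c(CC(=O)OCC(C)C)c(=O)n1Cc1ccc(-c2ccccc2-c2noc(=O)[nH]2)cc1` gives 7.7% in this assay. Within the data shown here, the one measured step, a number 3.7 percentage points higher from compound 2 to compound 3 (within the scatter), leaves compound 2 and compound 3 together at the low end of the series; the two entries of compound 1 cannot be set against them as one number.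

Compound 4 `CCCCc1nc(C)c(CC(=O)OCC2CC2)c(=O)n1Cc1ccc(-c2ccccc2-c2noc(=O)[nH]2)cc1` differs from compound 3 by cyclopropyl in place of isopropyl on a saturated chain carbon bound to an oxygen next to a carbonyl group. Among the measured compounds shown here, the only step that bears on this change is a number 3.7 percentage points higher from compound 2 to compound 3 (within the scatter), which altered the same chain on the oxygen next to a carbonyl group by a comparable amount and stayed within the scatter. For the measured compounds named here, nothing among the measured compounds points to a shift beyond the scatter in this assay for the present change, in either direction. The step expected is therefore a number 4.3 percentage points higher from compound 3 to compound 4 (within the scatter). Compound 4 is estimated at 12% in this assay, with a range from 3% to 35%.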

Compound 4, percent of the compound remaining: 13%
The estimate for compound 4 lay 1 percentage points below the measured number, and the stated range covers the measured number.
By their numbers in this assay, from the lowest: compounds 2, 3 and 4 (each within the scatter of the next).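

The change from isopropyl to cyclopropyl on a saturated chain carbon bound to an oxygen next to a carbonyl group brings in one three-membered non-aromatic ring of carbon only, with the count of heavy atoms unchanged, and in this assay it gives a number 5.3 percentage points higher from compound 3 to compound 4 (within the scatter). The wider comparison gives a number 9 percentage points higher from compound 2 to compound 4 (within the scatter), so this step also stays inside the usual scatter. A ring at this position therefore adds a second kind of chain to the series, yet isopropyl, isobutyl and cyclopropylmethyl cannot be told apart in this assay.

Going by these compounds, whether an amine, a carboxylic acid or a longer chain on this oxygen would move the number beyond the scatter remains open. Compound 1 also remains unplaced against compound 2, compound 3 and compound 4, because its two entries do not agree: the several entries of compound 1 in this assay, 12.9%; 78.4% (2 entries)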